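From pyrrolidin-2-yl to piperidin-4-yl on a shared core

The source may report more compounds than this note shows. Statements on the series, on what has been measured and on what is new or still open speak of the compounds shown alone.

Compound 1 (`COc1ccc(-c2noc(-c3ccncc3)n2)cc1OC1CCCC1`) and compound 2 (`COc1ccc(-c2noc(C3CCCN3)n2)cc1OC1CCCC1`) share one core and differ only in the group on an aromatic carbon. In a functional assay on MCF7 cells (Homo sapiens) for antiproliferative activity, read by MTT assay, with a stated time of 24 h (a lower number here means a stronger inhibitor, a higher number a weaker inhibitor), compound 1 gives > 1000000 nM, which is a limit of the assay and not a number. In this assay compound 2 gives > 1000000 nM, which is also a limit. Compound 2 therefore has no number of its own and stands at the limit of > 1000000 nM in this assay, at which 2 of the 2 values shown sit.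

Compound 3 (`COc1ccc(-c2noc(C3CCNCC3)n2)cc1OC1CCCC1`) changes the same group: piperidin-4-yl in place of pyrrolidin-2-yl on an aromatic carbon. Going by the values given here, the one measured step that bears on this change is a step that the two limits leave unreadable from compound 1 to compound 2, a swap at the same place. It offers no size to carry forward, so the data give no ground for expecting a step beyond the scatter in this assay. The most likely outcome is another result reported only as a limit. The estimate for compound 3 is 1000000 nM, with an expected range from 300000 nM to 3000000 nM. This estimate means an expected a number no higher from compound 2 to compound 3 (the limit leaves the size open).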

Compound 3, half-maximal inhibitory concentration: 3880 nM
Beside the measured number, compound 3's estimate is 260-fold (2.41 log units) above it, and the stated range ends above it.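

This position on the shared core can clearly change the result in this assay: the change to piperidin-4-yl gives an at least 250-fold lower number from compound 2 to compound 3 (2.41 log units; beyond the scatter), and the comparison with the pyridin-4-yl group gives an at least 250-fold lower number from compound 1 to compound 3 (2.41 log units; beyond the scatter). Pyrrolidin-2-yl and piperidin-4-yl each carry 1 hydrogen-bond donor, 1 hydrogen-bond acceptor and no net charge, so these counts do not separate compound 2 from compound 3, while the two groups differ in ring size and in where the ring is attached. Both steps are minimum sizes, as compound 1 and compound 2 have only limits and no numbers of their own: the limit of > 1000000 nM in this assay, at which 2 of the 3 values shown sit.

The compounds shown leave open whether ring size or point of attachment matters more, a question that piperidin-2-yl or pyrrolidin-3-yl on the same core could help to settle. They also leave open how the result would respond to a methyl group or an acetyl group on the ring nitrogen of piperidin-4-yl, or to an open-chain amine such as aminomethyl in its place.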